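The source may report more compounds than this note shows. Statements on the series, on what has been measured and on what is new or still open speak of the compounds shown alone.

Measured so far in an ADME assay (liver) for metabolic stability, with Liver microsome (Homo sapiens) as the target, read by LC-MS, using microsomes, with a stated time of 30 min, tested at 4 uM; a higher number here means that more of the compound is left, a lower number that less of the compound is left:
compound 1 `Cc1nc(N2CCN(C)CC2)c2nc(-c3cccc(C(F)(F)F)c3)n(C3CCOCC3)c2n1`: 19%
compound 2 `COc1ccccc1-c1nc2c(N3CCN(C)CC3)nc(C)nc2n1C1CCOCC1`: 22%
compound 3 `Cc1nc(N2CCN(C)CC2)c2nc(-c3ccccc3C3CC3)n(C3CCOCC3)c2n1`: 33%

All three compounds share one core and differ only in the aryl group. Compound 3 stands highest of the three at 33%, and its steps to both others lie beyond the scatter.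

The unmeasured compound 4 `CCc1ccccc1-c1nc2c(N3CCN(C)CC3)nc(C)nc2n1C1CCOCC1` has ethyl in place of cyclopropyl on an aromatic carbon, ortho to a large group: ethyl in place of cyclopropyl on an aromatic carbon. The same difference, cut one bond further out, reads 2-cyclopropylphenyl to 2-ethylphenyl.

The closest measured evidence is a number 11 percentage points higher from compound 2 to compound 3 (beyond the scatter), which brings in the same cyclopropyl in place of methoxy. A modest step of similar size is a number 14 percentage points higher from compound 1 to compound 3 (beyond the scatter), for 2-cyclopropylphenyl in place of 3-(trifluoromethyl)phenyl. By contrast, a number 3 percentage points higher from compound 1 to compound 2 (within the scatter) shows that a change of aryl group need not move the number beyond the scatter. Among the compounds with values here, no measured step replaces cyclopropyl with another group made of carbon only, so these steps bound the size only loosely.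

In this assay, a small fall that stays within the scatter is expected, smaller than the two modest steps. The expected step is a number 5 percentage points lower from compound 3 to compound 4 (within the scatter). For compound 4 the estimate is 28%, with an expected range of 16% to 41%.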

Compound 4, percent of the compound remaining: 33%
Compound 4: middle estimate off by 5 percentage points, on the low side, within the range that was stated.
By their numbers in this assay, from the lowest: compounds 1 and 2 (each within the scatter of the next); then compounds 3 and 4 (each within the scatter of the next).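

In this assay, the three-membered ring of cyclopropyl can be given up on this aromatic carbon, ortho to a large group, without a step beyond the scatter: ethyl in its place gives no change at the digits printed from compound 3 to compound 4 (within the scatter) and leaves the reading where it stood. The separation from the other two aryl groups is therefore not tied to cyclopropyl alone, as ethyl also gives a number 11 percentage points higher from compound 2 to compound 4 (beyond the scatter) and a number 14 percentage points higher from compound 1 to compound 4 (beyond the scatter), the second of these with the aryl substituent in a different place as well as of a different kind. Nothing measured here accounts for these readings.

Still open, on these data alone, is how far this tolerance runs among carbon-only groups at the same place, for instance whether a methyl, an isopropyl or a longer chain such as n-butyl stays with compound 3 and compound 4 or falls back towards compound 2. Within the data shown here, equally open is whether a group carrying an amine or a carboxylic acid at this place fits the same picture, as the only non-carbon group at this place so far is the methoxy of compound 2.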